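Swapping a pyrrolidinone for a pyrrole on a second core

The source may report more compounds than this note shows. Statements on the series, on what has been measured and on what is new or still open speak of the compounds shown alone.

Of the compounds shown here, three have been tested in an ADME assay on HEL cells (Homo sapiens) for cytotoxicity, with a stated time of 3 days; a lower number here means that less compound is tolerated, a higher number that more compound is tolerated. Compound 1 `Cc1cc(N2CCCC2=O)cn2c(CSCCc3ccccc3)cnc12` gives 89 ug/mL in this assay, compound 2 `Cc1cc(-n2cccc2)cn2c(CSCCc3ccccc3)cnc12` gives 11 ug/mL, and compound 3 `Cc1cc(N2CCCC2=O)c2ncc(CSCCc3ccccc3)n2c1` gives 25 ug/mL. Compound 3 carries the same atoms as compound 1 joined in a different way; the difference between the two cores is not broken down here.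

From compound 1 to compound 2 the change is 1H-pyrrol-1-yl in place of 2-oxopyrrolidin-1-yl on an aromatic carbon, and it produced an 8.1-fold lower number from compound 1 to compound 2 (0.91 log units; beyond the scatter). Compound 4 `Cc1cc(-n2cccc2)c2ncc(CSCCc3ccccc3)n2c1`, still unmeasured in this assay, carries the same kind of change on the core of compound 3, namely (1H-pyrrol-1-yl in place of 2-oxopyrrolidin-1-yl on an aromatic carbon). The surroundings are not identical: in compound 4 the group sits ortho to a fused ring, whereas in compound 2 it sits para to a fused ring.

Because compound 1 to compound 2 gave an 8.1-fold lower number from compound 1 to compound 2 (0.91 log units; beyond the scatter), a step of similar direction is expected here, though its size on a different core is uncertain, so the expected step is a 6.3-fold lower number from compound 3 to compound 4 (0.80 log units; beyond the scatter). Compound 4 is therefore estimated at 4 ug/mL in this assay, between 1.5 ug/mL and 12 ug/mL.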

Compound 4, half-maximal cytotoxic concentration: 26 ug/mL
The estimate for compound 4 lay 6.5-fold (0.81 log units) below the measured number; measured number above the stated range.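

In this assay, putting 1H-pyrrol-1-yl in place of 2-oxopyrrolidin-1-yl gave a 1.0-fold higher number from compound 3 to compound 4 (0.02 log units; within the scatter) and so made no readable difference on the core of compound 3, whereas the same change made a clear difference on the core of compound 1. Set side by side, the step did not carry over from one core to the other: the same change on two cores in this assay, an 8.1-fold lower number (0.91 log units; beyond the scatter) from compound 1 to compound 2 and a 1.0-fold higher number (0.02 log units; within the scatter) from compound 3 to compound 4, 8.4-fold (0.93 log units) apart, beyond the scatter of two such steps. For these two cores, then, the result of this change on one is a poor guide to its result on the other, but the data do not show why the cores differ, and a single pair of steps says nothing about how the change would behave on any further core.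

From the compounds shown here alone, whether the two cores would also give different steps for another group at this place, such as an amine or a carboxylic acid, stays open. Among the compounds shown here, also open is whether the change on a third core would resemble the step seen on compound 1 or the one seen on compound 3.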